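This account rests on a few compounds, and the source may have more. Where it says the series, first, only, none or still open, it means among the compounds named here.

Compound 1 `COC(=O)/C=C/c1cccc(N(Cc2ccc(/C=C/c3c(Cl)cccc3Cl)cc2)C(=O)C(C)C)c1` gives 195 nM in an assay on isolated protein with Bile acid receptor (Homo sapiens) as the target; on this read-out lower numbers stand for an effect already at smaller amounts and higher numbers for an effect only at larger amounts of compound. Compound 2 `COC(=O)/C=C/c1cccc(N(Cc2ccc(-c3cccc(Cl)c3)cc2)C(=O)C(C)C)c1` gives 77 nM in this assay. Compound 3 `COC(=O)/C=C/c1cccc(N(Cc2ccc(-c3ccc(F)c(Cl)c3)cc2)C(=O)C2CCCCC2)c1` gives 66 nM in this assay.

Compound 3 has the lowest of the three numbers, but its gap to compound 2 lies within the scatter, so the two cannot be ranked; only against compound 1 does compound 3 stand clearly apart. Compound 4 `COC(=O)/C=C/c1cccc(N(Cc2ccc(-c3cccc(C(C)=O)c3)cc2)C(=O)C2CCCCC2)c1` differs from compound 3 in one place: 3-acetylphenyl in place of 3-chloro-4-fluorophenyl on an aromatic carbon. Going by the values given here, the single measured step, a 2.5-fold lower number from compound 1 to compound 2 (0.40 log units; beyond the scatter), changes the same end of the molecule, although a different group, and shows that this region moves the number only modestly. Among the compounds with values here, no step exchanges a halogenated phenyl for an acetyl-bearing one, so the direction cannot be read from the data; a step of modest size, either way, is the most that can be expected. Compound 4 is therefore estimated at 110 nM in this assay, with a range from 40 nM to 350 nM, a step of a 1.7-fold higher number from compound 3 to compound 4 (0.22 log units; within the scatter) that is expected to stay close to the scatter.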

Compound 4, half-maximal effective concentration: 227 nM
Compound 4: middle estimate off by 2.1-fold (0.31 log units), on the low side, within the range that was stated.
By their numbers in this assay, from the lowest: compounds 3 and 2 (each within the scatter of the next); then compounds 1 and 4 (each within the scatter of the next).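

In this assay the exchange of 3-chloro-4-fluorophenyl for 3-acetylphenyl, on an aromatic carbon para to a large group, gives a 3.4-fold higher number from compound 3 to compound 4 (0.54 log units; beyond the scatter) and thereby settles the direction for this pair: the acetyl-bearing ring has the higher number. Together with a 2.5-fold lower number from compound 1 to compound 2 (0.40 log units; beyond the scatter) this makes a second measured step at the same end of the molecule that lies beyond the scatter, so this position clearly influences the number, though both steps remain modest. Nothing available explains why the acetyl-bearing compound has the higher number.

The pair removes both halogens and adds the acetyl group in one exchange, so it does not separate their shares in the step. As far as these compounds go, it also remains open whether an amine or a carboxylic acid in place of the acetyl group would bring the number back towards that of compound 3.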